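Series notes: aryl change from compound 1 to compound 4

The source may hold more compounds than are shown below. What is called first, only, known or untested is meant among the compounds shown, and "the series" means these compounds.

Measured compounds:
Compound 1 `CCc1ccc(-n2nc(-c3ccc(C(F)(F)F)cc3O)nc2-c2ccccc2O)cc1` gives 64.4% in a functional assay on PC-12 cells (Rattus norvegicus) for cytotoxicity, read by MTT assay, with stated times of 2 h and 24 h, tested at 1 uM; on this read-out lower numbers stand for a weaker effect and higher numbers for a stronger effect at the one concentration tested.
Compound 2 `CC(C)c1ccc(-n2nc(-c3ccc(C(F)(F)F)cc3O)nc2-c2ccccc2O)cc1` gives 69.7% in this assay.
Compound 3 `N#Cc1ccc(-n2nc(-c3ccc(C(F)(F)F)cc3O)nc2-c2ccccc2O)cc1` gives 66.6% in this assay.

On this assay compound 1 has the lowest of the three numbers, but neither neighbour is separated from it: the nearest step is a number 2.2 percentage points higher from compound 1 to compound 3 (within the scatter) and the furthest is a number 5.3 percentage points higher from compound 1 to compound 2 (within the scatter). The remaining pair shows a number 3.1 percentage points lower from compound 2 to compound 3 (within the scatter). All three measured compounds therefore sit together within the scatter, and no order among them can be read off.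

Compound 4 `Oc1cc(C(F)(F)F)ccc1-c1nc(-c2ccccc2O)n(-c2ccc(F)cc2F)n1` differs from compound 1 in one place: 2,4-difluorophenyl in place of 4-ethylphenyl on an aromatic nitrogen. The three measured steps all concern the group on the same aromatic nitrogen of the five-membered aromatic ring with 3 nitrogen, so each of them bears on this change. Exchanging ethyl for isopropyl, ethyl for cyano or isopropyl for cyano at that position left the read-out within the scatter every time. The expectation for 2,4-difluorophenyl entering in place of 4-ethylphenyl is the same: no step beyond the scatter in either direction.

Compound 4 is expected to give 66%, with a range from 54% to 78%. The estimated step of a number 1.6 percentage points higher from compound 1 to compound 4 (within the scatter) is expected to stay within the scatter.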

Compound 4, a percentage reported as activity, at one concentration (the size of the read-out at that concentration, not a potency): 65.9%
Compound 4: the middle estimate sits 0.1 percentage points above what was measured; the measured number falls inside the stated range.
By their numbers in this assay, from the lowest: compounds 1, 4, 3 and 2 (each within the scatter of the next).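

With 2,4-difluorophenyl, the group on the aromatic nitrogen changes from the earlier single-substituent aryl groups to one carrying 2 fluorine, yet in this assay all three new comparisons stay within the scatter: a number 1.5 percentage points higher from compound 1 to compound 4 (within the scatter), a number 0.7 percentage points lower from compound 3 to compound 4 (within the scatter) and a number 3.8 percentage points lower from compound 2 to compound 4 (within the scatter). The insensitivity seen among 4-ethylphenyl, 4-isopropylphenyl and 4-cyanophenyl therefore extends to a different substitution pattern of the same heavy-atom count as 4-ethylphenyl, and compounds 1, 2, 3 and 4 remain unresolved from one another at the one concentration tested. Nothing measured here explains why these aryl changes leave the read-out within the scatter.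

Still open, as far as these compounds go, is whether this flat response holds for groups further from these substituted phenyls, such as a phenyl carrying an amine or a carboxylic acid, or a longer alkyl chain in place of the aryl group. From the compounds shown here alone, the shared core is also untested by these four compounds, so it remains unknown whether replacing a hydroxyl with a methoxy group, or the trifluoromethyl with a hydrogen, would produce a step beyond the scatter.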